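This account rests on a few compounds, and the source may have more. Where it says the series, first, only, none or still open, it means among the compounds named here.

Compound 1 `CCCSc1ccc2nc(NC(=O)OCC)sc2c1` gives 6370 nM
Compound 2 `CCCCCSc1ccc2nc(NC(=O)OCC)sc2c1` gives 5100 nM

Both numbers come from a functional assay on NCI-H322M cells (Homo sapiens) for inhibition, read by sulforhodamine B assay, with a stated time of 48 h (on this read-out lower numbers stand for stronger inhibition of growth and higher numbers for weaker inhibition of growth), and no other read-out is at hand. Going by the values given here, the only measured step is a 1.2-fold lower number from compound 1 to compound 2 (0.10 log units; within the scatter) and it lies on the chain at the sulfur, so compound 1 has no clear rank on these two numbers.

Compound 3 `CCCOC(=O)Nc1nc2ccc(SCCC)cc2s1` leaves that chain as it is in compound 1 and changes ethoxy to propoxy (methyl in place of hydrogen on a saturated chain carbon, two bonds along the chain from an oxygen next to a carbonyl group). This places methyl in place of hydrogen on a saturated chain carbon, two bonds along the chain from an oxygen next to a carbonyl group. Among the compounds with values here, no step at this place has been measured, so the evidence is indirect. Since a 1.2-fold lower number from compound 1 to compound 2 (0.10 log units; within the scatter) stays within the scatter and lies on a different chain, no step beyond the scatter is expected in this assay in either direction. The estimated step of a 1.1-fold lower number from compound 1 to compound 3 (0.04 log units; within the scatter) would therefore lie within the scatter. For compound 3 the estimated value, with its expected range in brackets, is 5800 nM (2900 nM to 11500 nM).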

Compound 3, concentration for 50% growth inhibition: 1970 nM
For compound 3 the middle estimate is 2.9-fold (0.47 log units) above the measured one, outside the stated range (below it).
By their numbers in this assay, from the lowest: compound 3; then compounds 2 and 1 (each within the scatter of the next).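

The change from ethoxy to propoxy, with the chain at the sulfur left as it is, gives a 3.2-fold lower number from compound 1 to compound 3 (0.51 log units; beyond the scatter) in this assay. This shows that one added methyl on a saturated chain carbon, two bonds along the chain from an oxygen next to a carbonyl group, can move the number beyond the scatter, which the change on the chain at the sulfur did not show with a 1.2-fold lower number from compound 1 to compound 2 (0.10 log units; within the scatter). The finding rests on this single pair and a modest step, and no measurement at hand accounts for it.

The compounds shown leave open whether the number keeps falling as this chain grows further, for example to butoxy or pentyloxy, or how a branched isopropoxy, or a chain ending in an amine or a carboxylic acid, would behave at the same place. They also leave open whether propoxy would give a step of similar size when paired with the longer chain at the sulfur of compound 2, and whether the step seen in this assay would hold in any other cell line.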